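Extending an Ethoxy Chain: Expected Effect on Cell Toxicity

A few compounds are considered here, and "the series" means these few. Any claim that something is new, unique, unknown or untested is made for them only; others in the source may bear on it.

Compound 1 `Nc1nc(OCC(F)(F)F)c2ncn(/C=C3/CC3(CO)CO)c2n1` — in an ADME assay on BCBL1 cells (Homo sapiens) for cytotoxicity, with a stated time of 7 days (on this read-out lower numbers stand for higher toxicity in this test and higher numbers for lower toxicity in this test), compound 1 gives > 20000 nM, which is a limit of the assay rather than a number.
Compound 2 `CCOc1nc(N)nc2c1ncn2/C=C1/CC1(CO)CO` — in this assay compound 2 gives > 20000 nM, also a limit.
Compound 3 `CC(C)CNc1nc(N)nc2c1ncn2/C=C1/CC1(CO)CO` — in this assay compound 3 gives > 20000 nM, again a limit.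

Compound 2 therefore stands at the limit shared by all three measured compounds (the limit of > 20000 nM in this assay, at which 3 of the 3 values shown sit). Compound 4 `CCCCCOc1nc(N)nc2c1ncn2/C=C1/CC1(CO)CO` differs from compound 2 by propyl in place of hydrogen on a saturated chain carbon, two bonds along the chain from an oxygen on an aromatic ring. The steps that might bear on this change are a step that the two limits leave unreadable from compound 1 to compound 2, a step that the two limits leave unreadable from compound 1 to compound 3 and a step that the two limits leave unreadable from compound 2 to compound 3. Among the compounds with values here, each of these steps is unreadable: both of its ends are limits, so no measured step gives a size or a direction. For compound 4, the most likely outcome is that this assay again reports only the limit, and the step that the limit leaves unreadable from compound 2 to compound 4 is expected to be none beyond the scatter. The estimate for compound 4 is 25000 nM, with an expected range from 10000 nM to 80000 nM.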

Compound 4, half-maximal cytotoxic concentration: > 20000 nM
Compound 4 ended at the assay's limit; the forecaster's own chance of this, stated with the estimate: 85%; the middle value lies beyond the limit too.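

No new step can be read: compound 4 sits at the same limit as compound 1, compound 2 and compound 3, so neither size nor direction shows: the limit of > 20000 nM in this assay, at which 4 of the 4 values shown sit.

The compounds shown leave open whether pentyloxy in place of ethoxy changes toxicity at all in this assay.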